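The compounds below may be only part of what the source reports. "The series", "measured", "known", "first", "only" and "open" are said of these compounds alone.

Of the compounds shown here, two have been measured for inhibition of growth. In a functional assay on PC-3 cells (Homo sapiens) for inhibition, read by MTT assay, with a stated time of 72 h (on this read-out lower numbers stand for stronger inhibition of growth and higher numbers for weaker inhibition of growth), compound 1, `CC(C)C[C@H](NC(=O)[C@@H](NS(=O)(=O)c1ccc(/N=N/c2ccccc2)cc1)C(C)C)C(=O)C(N)=O`, gives 24100 nM. Compound 2, `CC(C)C[C@@H](C=O)NC(=O)[C@@H](NS(=O)(=O)c1ccc(/C=C/c2ccccc2)cc1)C(C)C`, gives 23000 nM in this assay; of the two numbers, this one and that of compound 1 lie within the usual scatter of each other, so they cannot be told apart. Compound 3, `CC(C)C[C@H](NC(=O)[C@@H](NS(=O)(=O)c1ccc(/C=C/c2ccccc2)cc1)C(C)C)C(=O)C(N)=O`, has not yet been measured. It differs from compound 2 by carbamoyl in place of hydrogen on a carbonyl carbon. Among the compounds with values here, no measured pair in this set isolates that change, so the expected size of the step from compound 2 to compound 3 in this assay rests on the two numbers alone, which both sit in the same weak range. The step is expected to be a 1.0-fold lower number from compound 2 to compound 3 (0.02 log units; within the scatter), that is, none beyond the scatter in either direction. Compound 3 is therefore estimated at 22000 nM, with a range from 8000 nM to 60000 nM.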

Compound 3, concentration for 50% growth inhibition: 6020 nM
Estimate against measurement, compound 3: 3.7-fold (0.56 log units) above; the measured number lies below the stated range.
By their numbers in this assay, from the lowest: compound 3; then compounds 2 and 1 (each within the scatter of the next).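

In this assay, carbamoyl in place of hydrogen on a carbonyl carbon gives a 3.8-fold lower number from compound 2 to compound 3 (0.58 log units; beyond the scatter), the first sign that this position affects growth inhibition, a change that the near-equal values of the two earlier compounds could not reveal. With the carbamoylcarbonyl end held constant, the group of 8 carbon atoms in place of the group of 6 carbon and 2 nitrogen atoms on an aromatic carbon gives a 4.0-fold lower number from compound 1 to compound 3 (0.60 log units; beyond the scatter), so this second position also matters. Nothing available here accounts for either step.

The compounds shown leave open how a carboxylic acid or a methyl ester would compare with carbamoyl on that carbonyl carbon. They also leave open whether carbamoyl gives a step of similar size when the group with 2 nitrogen atoms sits on the aromatic carbon.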